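Swapping One Side Chain for Another in an Analgesia Series

A few compounds are considered here, and "the series" means these few. Any claim that something is new, unique, unknown or untested is made for them only; others in the source may bear on it.

Compounds measured so far:
Compound 1, `N=C(N)NCCC[C@H](NC(=O)CN(c1ncnc2c1ncn2C1CCCCO1)C1CC1)C(=O)OCc1ccccc1`: 61.6%
Compound 2, `CC(C)[C@H](NC(=O)CN(c1nc(Cl)nc2[nH]cnc12)C1CC1)C(=O)OCc1ccccc1`: 51.3%

Both were tested in a functional assay on the whole organism (Tail, strain ICR) with Mus musculus as the target, in the tail flick test, with a stated time of 90 min, at a dose of 25 umol/kg by the oral route; on this read-out lower numbers stand for a weaker effect and higher numbers for a stronger effect at the one dose given. Of the two numbers, compound 1 stands highest; compound 2 lies lower by a distance beyond the usual scatter. Going by the values given here, no pair differing in a single place has been measured, so nothing here shows how one change alone moves the read-out. Compound 3, `CC(C)(C)OC(=O)NCCCC[C@H](NC(=O)CN(c1ncnc2c1ncn2C1CCCCO1)C1CC1)C(=O)OCc1ccccc1`, is compound 1 carrying a group of 9 heavy atoms (6 carbon, 1 nitrogen, 2 oxygen; no ring) in place of a group of 4 heavy atoms (1 carbon, 3 nitrogen; no ring), on a saturated chain carbon, four bonds along the chain from an amide-type nitrogen and a carbonyl carbon on the saturated chain carbon. Among the compounds with values here, with no comparable step to lean on, the expected step is a number 16.6 percentage points lower from compound 1 to compound 3 (beyond the scatter), a moderate drop with wide uncertainty. Compound 3 is estimated at 45%, within 20% to 70%.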

Compound 3, a percentage reported as activity, at one dose (the size of the read-out at that dose, not a potency): 32.9%
Compound 3: the middle estimate sits 12.1 percentage points above what was measured; the range from low to high includes it.
By their numbers in this assay, from the lowest: compound 3; then compound 2; then compound 1.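

In this assay, going by these compounds alone, a single change can be read for the first time: ((tert-butoxycarbonyl)amino)methyl replacing the group of 4 heavy atoms on this saturated chain carbon gives a number 28.7 percentage points lower from compound 1 to compound 3 (beyond the scatter) on an otherwise unchanged structure. What sits at this place therefore matters for the effect at this dose, though one step cannot show which feature of the swap counts. No other measurement is available to explain the step. Where a simple amine or a carboxylic acid at this place would fall remains open, as does the effect of a shorter chain.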